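Nitro in Place of Methoxy: Expected Outcome for Compound 4

This account rests on a few compounds, and the source may have more. Where it says the series, first, only, none or still open, it means among the compounds named here.

Three compounds have been measured in a toxicity assay on L02 cells (Homo sapiens) for inhibition, read by CCK-8 assay, with a stated time of 72 h, tested at 20 uM; a lower number here means less inhibition of growth, a higher number more inhibition of growth at the concentration tested:
compound 1 `CC(C)(C)OC(=O)/C=C1/C(=O)Nc2ccccc21` gives 64.1%;
compound 2 `CC(C)c1ccc2c(c1)/C(=C\C(=O)OC(C)(C)C)C(=O)N2` gives 63.8%;
compound 3 `COc1ccc2c(c1)/C(=C\C(=O)OC(C)(C)C)C(=O)N2` gives 63.7%.

Compound 3 carries the lowest number of the three, but neither gap separates it from the others: a number 0.4 percentage points lower from compound 1 to compound 3 (within the scatter) and a number 0.1 percentage points lower from compound 2 to compound 3 (within the scatter) both stay within the scatter, as does a number 0.3 percentage points lower from compound 1 to compound 2 (within the scatter).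

Compound 4 `CC(C)(C)OC(=O)/C=C1/C(=O)Nc2ccc([N+](=O)[O-])cc21` arises from compound 3 by the change (nitro in place of methoxy on an aromatic carbon). The measured steps that bear on this position all involve swapping groups on the same aromatic carbon, and none moved this assay beyond the scatter. By that record, the step is expected to be a number 0.3 percentage points higher from compound 3 to compound 4 (within the scatter). Compound 4 is therefore estimated at 64%, with a range from 53% to 75%.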

Compound 4, percent growth inhibition at one concentration: 62%
Compound 4: the middle estimate sits 2 percentage points above what was measured; low and high end bracket the measured number.
By their numbers in this assay, from the lowest: compounds 4, 3, 2 and 1 (each within the scatter of the next).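

The record shows a number 1.7 percentage points lower from compound 3 to compound 4 (within the scatter) and a number 1.8 percentage points lower from compound 2 to compound 4 (within the scatter) and also a number 2.1 percentage points lower from compound 1 to compound 4 (within the scatter) as nitro enters this aromatic carbon. Nitro thus joins hydrogen, isopropyl and methoxy as a fourth substituent here that stays within the scatter of the others, even with its nitrogen and two hydrogen-bond acceptors. No measurement at hand offers an explanation for this.

The compounds shown leave open whether an amine or a carboxylic acid on this carbon would move this assay beyond the scatter. They also leave open whether other aromatic carbons of the shared core would tolerate such swaps alike.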